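Series notes: propyl in place of cyano on the aromatic ring

This account rests on a few compounds, and the source may have more. Where it says the series, first, only, none or still open, it means among the compounds named here.

Measured so far in a functional assay on aorta for antagonist activity at Alpha-1D adrenergic receptor (Rattus norvegicus); on this read-out lower numbers stand for tighter binding and higher numbers for weaker binding:
Compound 1, `CNC(=O)c1cccnc1NCCCN1CCN(c2ccccc2OC)CC1`, gives 3.16 nM.
Compound 2, `COc1ccccc1N1CCN(CCCNc2ccccc2C(=O)c2ccccc2)CC1`, gives 10 nM.
Compound 3, `CN(C)C(=O)c1cccnc1NCCCN1CCN(c2ccccc2C#N)CC1`, gives 10 nM.

Compound 3 stands level with compound 2 at the digits shown, the two together the highest numbers of the three; the furthest off is compound 1, whose lower number lies beyond the scatter. Among the measured compounds shown here, no two measured compounds differ in one place only, so no single-change step is known.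

Compound 4, `CCCc1ccccc1N1CCN(CCCNc2ncccc2C(=O)N(C)C)CC1`, is the next to be measured in this assay. It differs from compound 3 in one place: propyl in place of cyano on an aromatic carbon. Nothing measured sets the size of this change; the expected step of no change at the digits printed from compound 3 to compound 4 (within the scatter) is none beyond the scatter, in neither direction. Compound 4 is estimated at 10 nM, between 3 nM and 32 nM.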

Compound 4, dissociation constant: 31.6 nM
Compound 4: the middle estimate sits 3.2-fold (0.50 log units) below what was measured; the range from low to high includes it.
By their numbers in this assay, from the lowest: compound 1; then compounds 2 and 3 (each within the scatter of the next); then compound 4.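

In this assay, among the compounds shown here, this aromatic carbon, ortho to a large group, is the first position with a single-change reading: propyl in place of cyano gives a 3.2-fold higher number from compound 3 to compound 4 (0.50 log units; beyond the scatter). The position is therefore sensitive to this exchange, in which a hydrogen-bond acceptor leaves and none enters. Nothing available explains the step. Going by these compounds, whether the acceptor count or the change of group matters more remains open. So does the effect of an amine, a hydroxyl or a longer chain such as butyl on this carbon.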